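The source may hold more compounds than are shown below. What is called first, only, known or untested is meant among the compounds shown, and "the series" means these compounds.

Compound 1 `N/C(=N\NC(=S)N1CCSCC1)c1ccccn1` was examined in a functional assay on MCF7 cells (Homo sapiens) for cytotoxicity, read by MTT assay, with a stated time of 72 h, tested at 1 uM (on this read-out lower numbers stand for less inhibition of growth and higher numbers for more inhibition of growth at the one concentration tested), where compound 1 gives 16.3%. Two companions share its core and differ only in the ring on the thiocarbonyl carbon. Compound 2 `N/C(=N\NC(=S)N1CCCCC1)c1ccccn1` gives 15.4% in this assay, and compound 3 `N/C(=N\NC(=S)N1CCCC1)c1ccccn1` gives 45.9%. On these numbers compound 1 holds the second highest of three values: the step of a number 0.9 percentage points lower from compound 1 to compound 2 (within the scatter) lies within the scatter, whereas the step of a number 29.6 percentage points higher from compound 1 to compound 3 (beyond the scatter) lies beyond it, as does the step of a number 30.5 percentage points higher from compound 2 to compound 3 (beyond the scatter).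

Compound 4 `N/C(=N\NC(=S)N1CCSCC1)c1ccc(F)cn1` differs from compound 1 in one place: fluoro in place of hydrogen on an aromatic carbon. For the measured compounds named here, every measured step alters the ring on the thiocarbonyl carbon, and none touches the six-membered aromatic ring with one nitrogen, so no measured step bears on this change. With nothing pointing either way, the expected step is a number 1.7 percentage points higher from compound 1 to compound 4 (within the scatter), none beyond the scatter. Compound 4 is therefore estimated to give 18% in this assay, with a range from 5% to 35%.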

Compound 4, percent growth inhibition at one concentration: 30.6%
Beside the measured number, compound 4's estimate is 12.6 percentage points below it, and the stated range covers the measured number.
By their numbers in this assay, from the lowest: compounds 2 and 1 (each within the scatter of the next); then compound 4; then compound 3.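

For the compounds shown here, the six-membered aromatic ring with one nitrogen, untouched in the earlier compounds, proves to be a place where a small change counts: in this assay, fluoro in place of hydrogen gives a number 14.3 percentage points higher from compound 1 to compound 4 (beyond the scatter). This fluoro sits two atoms from the ring nitrogen and para to a large group, so the read-out responds to more than the ring on the thiocarbonyl carbon, and a single added atom is enough to take the step beyond the scatter. Nothing available explains how this fluoro raises growth inhibition.

As far as these compounds go, whether chloro, methoxy or an amine on the same carbon would move the number in the same direction remains open. Also open, from the compounds shown here alone, is whether fluoro would add to the effect of the pyrrolidin-1-yl ring in compound 3.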